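Dropping the Chloro Substituent: Compound 2 to Compound 3

The source may report more compounds than this note shows. Statements on the series, on what has been measured and on what is new or still open speak of the compounds shown alone.

Among the compounds with values here, compound 2 `O=c1c(C2N=C(c3ccccc3)SS2)coc2cc(Cl)ccc12` is the only compound with a definite number in a functional assay on COLO 205 cells (Homo sapiens) for inhibition, read by sulforhodamine B assay, with a stated time of 48 h (a higher number here means a weaker inhibitor, a lower number a stronger inhibitor), where compound 2 gives 76700 nM. Compound 1 `O=c1c(C2N=C(c3ccccc3)SS2)coc2ccc(F)cc12` reaches only a limit in this assay, > 100000 nM, which is the limit of > 100000 nM in this assay, at which 1 of the 2 values shown sits. Compound 3 `O=c1c(C2N=C(c3ccccc3)SS2)coc2ccccc12` differs from compound 2 by hydrogen in place of chloro on an aromatic carbon. Within the data shown here, no measured step of this kind is available, so the direction is uncertain; a small loss of potency, or no change beyond the scatter, is expected. Compound 3 is therefore estimated at 120000 nM, within 40000 nM to 400000 nM, and that expectation amounts to a 1.6-fold higher number from compound 2 to compound 3 (0.19 log units; within the scatter).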

Compound 3, half-maximal inhibitory concentration: > 100000 nM
Compound 3: a limit, no number (the forecaster's own chance of this, stated with the estimate: 55%); the middle value is on the limit's open side.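

In this assay, hydrogen in place of chloro on an aromatic carbon gives an at least 1.3-fold higher number from compound 2 to compound 3 (0.11 log units; that floor lies within the scatter). Compound 3 has only a limit, so this step is a floor and not a size: the chloro group may matter little or a great deal, but its removal yields no sign of a stronger inhibitor. The step between compound 1 and compound 3 cannot be read, because both values are limits: the limit of > 100000 nM in this assay, at which 2 of the 3 values shown sit.

From the compounds shown here alone, the true size of the chloro step remains open. So does whether another group on this aromatic carbon, such as an amine or a methoxy group, would give a stronger inhibitor.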